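The source may report more compounds than this note shows. Statements on the series, on what has been measured and on what is new or still open speak of the compounds shown alone.

Working notes on the series, read in an ADME assay on BHK-21 cells (Mesocricetus auratus) for cytotoxicity, read by MTT assay; a lower number here means that less compound is tolerated, a higher number that more compound is tolerated. Among the measured compounds shown here, compound 2 `COc1ccc(-c2nc3cc(/C(C)=N/NC(N)=S)ccc3n2C2CCCCC2)c(OC)c1` gives 17000 nM, the only actual number so far. Compound 1 `C/C(=N\NC(N)=S)c1ccc2c(c1)nc(-c1ccc(Cl)cc1)n2C1CCCCC1` gives > 100000 nM, which is a limit of the assay and not a number. That leaves compound 2 with no second number to be ranked against, only the comparison with this limit: the limit of > 100000 nM in this assay, at which 1 of the 2 values shown sits.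

Compound 3 `C/C(=N\NC(N)=S)c1ccc2c(c1)nc(-c1ccccn1)n2C1CCCCC1` carries pyridin-2-yl in place of 2,4-dimethoxyphenyl on an aromatic carbon of the shared core (pyridin-2-yl in place of 2,4-dimethoxyphenyl on an aromatic carbon). For the measured compounds named here, the same position changed in the one measured step, an at least 5.8-fold lower number from compound 1 to compound 2 (0.76 log units; beyond the scatter). There, 2,4-dimethoxyphenyl entered in place of 4-chlorophenyl. Compound 3 loses that group again, but pyridin-2-yl has not yet been measured here, so this single step is weak support.

A move back toward a higher number in this assay is expected, of modest size and with wide uncertainty: the expected step is a 2.4-fold higher number from compound 2 to compound 3 (0.37 log units; beyond the scatter). A reading at the limit remains possible. For compound 3 the estimated value is 40000 nM, with an expected range of 13000 nM to 100000 nM.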

Compound 3, half-maximal cytotoxic concentration: 24000 nM
Compound 3: middle estimate off by 1.7-fold (0.22 log units), on the high side; the measured number falls inside the stated range.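

In this assay, pyridin-2-yl in place of 2,4-dimethoxyphenyl gives a 1.4-fold higher number from compound 2 to compound 3 (0.15 log units; within the scatter), so these two groups cannot be told apart at this position on the present data. A second replacement of 4-chlorophenyl now points the same way, with an at least 4.1-fold lower number from compound 1 to compound 3 (0.61 log units; beyond the scatter) alongside an at least 5.8-fold lower number from compound 1 to compound 2 (0.76 log units; beyond the scatter), so the earlier drop is no longer tied to 2,4-dimethoxyphenyl alone, and among these three compounds only compound 1 stands apart. Compound 1 gives a limit of the assay and not a number, so both steps from it fix only a minimum size, because its true value lies out of reach: the limit of > 100000 nM in this assay, at which 1 of the 3 values shown sits.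

Going by these compounds, what remains open is whether the chlorine of 4-chlorophenyl is what sets compound 1 apart, a question that plain phenyl or 4-methoxyphenyl at the same position could address. On these data alone, it is also open how the number responds to an aminomethyl or carboxylic acid group on that aromatic ring, or to a short chain such as ethyl in place of the cyclohexyl group.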